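A Methylsulfonyl Group Enters the Cyclopentyl Compound

This account rests on a few compounds, and the source may have more. Where it says the series, first, only, none or still open, it means among the compounds named here.

In a functional assay on MCF7 cells (Homo sapiens) for cytotoxicity, read by MTT assay, with a stated time of 48 h (a higher number here means a weaker inhibitor of growth, a lower number a stronger inhibitor of growth), compound 1 (`CC(C)c1nc2cc(Cl)c(Cl)cc2[nH]1`) gives 57000 nM and compound 2 (`Clc1cc2ncn(C3CCCC3)c2cc1Cl`) gives 42000 nM so compound 2 stands within the scatter of compound 1. The change methylsulfonyl in place of hydrogen on an aromatic carbon leads to compound 3 (`CS(=O)(=O)c1nc2cc(Cl)c(Cl)cc2n1C1CCCC1`) and puts methylsulfonyl in place of hydrogen on an aromatic carbon, between two ring nitrogen atoms. Within the data shown here, no measured step bears on this change, so in this assay no shift beyond the scatter is expected, the estimated move being a 1.4-fold lower number from compound 2 to compound 3 (0.15 log units; within the scatter) at the middle of the range. For compound 3 the expected value is 30000 nM (range 8000 nM to 100000 nM).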

Compound 3, concentration for 50% growth inhibition: 600 nM
Compound 3: the middle estimate sits 50-fold (1.70 log units) above what was measured, and the stated range ends above it.
By their numbers in this assay, from the lowest: compound 3; then compounds 2 and 1 (each within the scatter of the next).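

In this assay, among these compounds, placing methylsulfonyl on the aromatic carbon between two ring nitrogen atoms gives a 70-fold lower number from compound 2 to compound 3 (1.85 log units; beyond the scatter) and is the first measured step at this position. It shows that, with a cyclopentyl group on the neighbouring ring atom, replacing hydrogen here can change the growth-inhibition number far beyond the scatter. No measurement shown accounts for the size of this step. The compounds shown leave open whether a methyl group, an amine or a methylthio group at this position would give a similar step, and whether methylsulfonyl would do so without the cyclopentyl group.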